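Ethylamino to Dimethylamino on Two Related Cores

The compounds below may be only part of what the source reports. "The series", "measured", "known", "first", "only" and "open" are said of these compounds alone.

Three compounds were measured in a functional assay on A549 cells (Homo sapiens) for antiproliferative activity, read by MTT assay, with a stated time of 48 h; on this read-out lower numbers stand for stronger inhibition and higher numbers for weaker inhibition:

Compound 1, `CCNCC(=O)Nc1cc(OC)ccc1C(=O)c1ccc(OC)c2c1OC(C)(C)C=C2`, gives 1050 nM.
Compound 2, `CCNCC(=O)Nc1cc(OC)ccc1C(=O)c1ccc2c(c1)C=CC(C)(C)O2`, gives 1300 nM.
Compound 3, `COc1ccc(C(=O)c2ccc(OC)c3c2OC(C)(C)C=C3)c(NC(=O)CN(C)C)c1`, gives 890 nM.

Compound 1 and compound 3 share one core and differ by a single change, (dimethylamino in place of ethylamino on a saturated chain carbon bound to a carbonyl carbon). The step that this change made is a 1.2-fold lower number from compound 1 to compound 3 (0.07 log units; within the scatter), so the two values stand together within the usual spread of this assay.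

Compound 2 carries a different core from compound 1; the difference between the two cores is not broken down here. Its value in this assay lies within the scatter of both compound 1 and compound 3, so nothing separates the three measured numbers.

Compound 4, `COc1ccc(C(=O)c2ccc3c(c2)C=CC(C)(C)O3)c(NC(=O)CN(C)C)c1`, has not yet been measured. It relates to compound 2 by dimethylamino in place of ethylamino on a saturated chain carbon bound to a carbonyl carbon, and the place of the change reads the same as for the pair of compound 1 and compound 3, so it is the same change carried onto the core of compound 2. Going by the values given here, the only guide is the step from compound 1 to compound 3, which stayed within the scatter; on that basis the step from compound 2 to compound 4 is expected to be a 1.2-fold lower number from compound 2 to compound 4 (0.07 log units; within the scatter), a small move of the same kind. Because compound 2 gives 1300 nM, compound 4 is estimated at 1100 nM in this assay, with a likely range from 600 nM to 2200 nM.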

Compound 4, half-maximal inhibitory concentration: 1160 nM
Estimate against measurement, compound 4: 1.1-fold (0.02 log units) below, within the range that was stated.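

In this assay, putting dimethylamino in place of ethylamino on the saturated chain carbon bound to a carbonyl carbon gives a 1.1-fold lower number from compound 2 to compound 4 (0.05 log units; within the scatter), so this step lies within the scatter, as the step on the other core did. Set side by side, the two steps show that the change behaves alike on both cores, with neither step nor the gap between them standing out from the usual spread of the measurements: the same change on two cores in this assay, a 1.2-fold lower number (0.07 log units; within the scatter) from compound 1 to compound 3 and a 1.1-fold lower number (0.05 log units; within the scatter) from compound 2 to compound 4, 1.1-fold (0.02 log units) apart, within the scatter of two such steps. This shows that, on these two cores, the change leaves the antiproliferative read-out where it was, but it does not show a real gain or loss of activity on either core, and two pairs cannot establish that the same would hold on a third core or explain why the change made so little difference.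

The compounds shown leave open whether any other group at this place would move the number beyond the scatter, such as a primary amine, diethylamino, a pyrrolidine or morpholine ring, or a carboxylic acid. They also leave open whether a longer chain between the amide and the amine would keep the same flat picture on either core.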